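Isopropyl in Place of Hydrogen on the Amide-Bound Chain Carbon

The compounds below may be only part of what the source reports. "The series", "measured", "known", "first", "only" and "open" are said of these compounds alone.

Compound 1 `O=C(CN(c1nc(Cl)nc2[nH]cnc12)C1CC1)N[C@@H](CO)C(=O)OCc1ccccc1`: 34.2%
Compound 2 `O=C(CN(c1nc(Cl)nc2[nH]cnc12)C1CC1)NCC(=O)OCc1ccccc1`: 41.9%

Among the measured compounds shown here, in a functional assay on the whole organism (Tail, strain ICR) with Mus musculus as the target, in the tail flick test, with a stated time of 60 min, at a dose of 25 umol/kg by the oral route (a higher number here means a stronger effect of the compound at the dose given, a lower number a weaker effect), compound 2 gives 41.9%, and the only other number, that of compound 1, lies within the scatter of it: a number 7.7 percentage points higher from compound 1 to compound 2 (within the scatter). Compound 3 `CC(C)[C@H](NC(=O)CN(c1nc(Cl)nc2[nH]cnc12)C1CC1)C(=O)OCc1ccccc1` differs from compound 2 by isopropyl in place of hydrogen on a saturated chain carbon bound to an amide-type nitrogen and a carbonyl carbon. For the measured compounds named here, the sole measured step at this same saturated chain carbon, a number 7.7 percentage points higher from compound 1 to compound 2 (within the scatter), stayed within the scatter, and no measured pair exchanges hydrogen for isopropyl there. Compound 3 is therefore expected to show no step beyond the scatter, a number 3.9 percentage points lower from compound 2 to compound 3 (within the scatter). Compound 3 is estimated at 38%, between 20% and 56%.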

Compound 3, a percentage reported as activity, at one dose (the size of the read-out at that dose, not a potency): 55.5%
The estimate for compound 3 lay 17.5 percentage points below the measured number; low and high end bracket the measured number.
By their numbers in this assay, from the lowest: compounds 1 and 2 (each within the scatter of the next); then compound 3.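

In this assay the saturated chain carbon bound to an amide-type nitrogen and a carbonyl carbon shows its first step beyond the scatter: isopropyl in place of hydrogen gives a number 13.6 percentage points higher from compound 2 to compound 3 (beyond the scatter) and isopropyl in place of hydroxymethyl gives a number 21.3 percentage points higher from compound 1 to compound 3 (beyond the scatter) here. Hydrogen and hydroxymethyl had stayed within the scatter of each other, so among these three groups only isopropyl stands apart. Nothing available explains this rise.

On these data alone, whether a longer chain such as n-butyl, or a benzyl group, would give a number beyond that of compound 3 stays open. So does the effect of an amine or a carboxylic acid on this carbon.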